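Amide nitrogen substitution in a vitamin D receptor agonist series

A few compounds are considered here, and "the series" means these few. Any claim that something is new, unique, unknown or untested is made for them only; others in the source may bear on it.

Measured compounds:
- compound 1, `CCn1c(C(=O)NCCCN(C)C)ccc1C(CC)(CC)c1ccc(OCCC(O)(CC)CC)c(C)c1`: 5 nM
- compound 2, `CCN(CC)CCNC(=O)c1ccc(C(CC)(CC)c2ccc(OCCC(O)(CC)CC)c(C)c2)n1CC`: 2.3 nM
- compound 3, `CCn1c(C(=O)Nc2cccc(C(F)(F)F)c2)ccc1C(CC)(CC)c1ccc(OCCC(O)(CC)CC)c(C)c1`: 5900 nM

All three share the core of compound 1 and differ only in what sits on the amide-type nitrogen. In an assay on cells for agonist activity at vitamin D3 receptor (Homo sapiens), with a stated time of 96 h (a lower number here means that less compound is needed, a higher number that more compound is needed for the effect), compound 1 stands second highest of the three numbers; compound 2 is nearest, with a 2.2-fold lower number from compound 1 to compound 2 (0.34 log units; beyond the scatter), while compound 3 is furthest, with a 1200-fold higher number from compound 1 to compound 3 (3.07 log units; beyond the scatter). The step of a 2600-fold higher number from compound 2 to compound 3 (3.41 log units; beyond the scatter) tells the same story from the other amine-bearing compound.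

Compound 4, `CCOC(=O)CN(C)C(=O)c1ccc(C(CC)(CC)c2ccc(OCCC(O)(CC)CC)c(C)c2)n1CC`, has not yet been measured. Relative to compound 1 the change is ((ethoxycarbonyl)methyl)(methyl)amino in place of (3-(dimethylamino)propyl)amino on a carbonyl carbon. The step from compound 1 to compound 3 bears on it most: that step swapped the amine-bearing chain for an aromatic group and cost a large amount; compound 4 likewise gives up the amine-bearing chain, though what enters is a short open chain rather than a ring, so the outcome is uncertain. The step from compound 1 to compound 2 shows only that changing the amine within the chain moves the number modestly.

A clear rise in the number, of intermediate size, is expected for compound 4, a 30-fold higher number from compound 1 to compound 4 (1.48 log units; beyond the scatter). The estimate for compound 4 in this assay is 150 nM, with a range of 20 nM to 1500 nM.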

Compound 4, half-maximal effective concentration: 520 nM
For compound 4 the middle estimate is 3.5-fold (0.54 log units) below the measured one; the measured number falls inside the stated range.
By their numbers in this assay, from the lowest: compound 2; then compound 1; then compound 4; then compound 3.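

In this assay, the ((ethoxycarbonyl)methyl)(methyl)amino group on the carbonyl carbon gives an intermediate result: a 100-fold higher number from compound 1 to compound 4 (2.02 log units; beyond the scatter) and a 230-fold higher number from compound 2 to compound 4 (2.35 log units; beyond the scatter), yet an 11-fold lower number from compound 3 to compound 4 (1.05 log units; beyond the scatter). The amine-bearing chains of compound 1 and compound 2 therefore remain clearly ahead, but giving up such a chain does not by itself bring the number up to that of compound 3, so the loss at this position is graded and depends on what enters. No measurement at hand explains the differences among these groups.

Compound 4 loses the amide hydrogen and the dimethylamino group together and gains an ester, so these changes cannot be separated; a (3-(dimethylamino)propyl)(methyl)amino group on the same carbonyl carbon would address the amide hydrogen alone. Also open, going by these compounds, is whether a carboxylic acid in place of the ethyl ester, or a (2-(ethoxycarbonyl)ethyl)amino group with a longer chain and the amide hydrogen retained, would move the number toward compound 1 or toward compound 3.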